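The compounds below may be only part of what the source reports. "The series", "measured", "known", "first", "only" and "open" are said of these compounds alone.

Measured in an ADME assay on THP-1 cells (Homo sapiens) for cytotoxicity, read by flow cytometry and propidium iodide staining, with a stated time of 72 h; on this read-out higher numbers stand for weaker inhibition and lower numbers for stronger inhibition:

- Compound 1 `Cc1nc(CS(=O)(=O)c2ccc(F)cc2)c([N+](=O)[O-])n1CCO`: > 728000 nM
- Compound 2 `Cc1ccc(S(=O)(=O)Cc2nc(C)n(CC(C)O)c2[N+](=O)[O-])cc1`: > 707000 nM
- Compound 3 `Cc1nc(CS(=O)(=O)c2ccc(Cl)cc2)c([N+](=O)[O-])n1CC(C)O`: > 688000 nM

Each of these three values is a limit and not a number. On these data alone, for compound 3 the reading is the limit of > 688000 nM in this assay, at which 1 of the 3 values shown sits, so its true position is unknown.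

Compound 4 `Cc1nc(CS(=O)(=O)c2ccc(F)cc2)c([N+](=O)[O-])n1CC(C)O` differs from compound 3 in one place: fluoro in place of chloro on an aromatic carbon. This is fluoro in place of chloro on an aromatic carbon, para to a large group, so 4-chlorophenyl becomes 4-fluorophenyl.

Among the measured compounds shown here, the one measured step at this group is a step that the two limits leave unreadable from compound 2 to compound 3, and it gives no size to carry over. Compound 1 already holds the 4-fluorophenyl group, though it has a different chain on the shared core. Compound 1 also gives a limit, > 728000 nM. Compound 3 is the closest relative of compound 4. Compound 3 sits at > 688000 nM, which is a limit, so no step beyond the scatter is expected in this assay, in either direction. The expected change is a step that the limit leaves unreadable from compound 3 to compound 4. The estimate for compound 4 is 700000 nM, with an expected range from 400000 nM to 1200000 nM, and the result will most likely be a limit again.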

Compound 4, half-maximal inhibitory concentration: > 699000 nM
Compound 4: only a limit was reported; the forecaster's own chance of this, stated with the estimate: 90%; the middle value does not contradict the limit.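

In this assay compound 4 gives > 699000 nM, which is a limit and not a number. Among the compounds shown here, compound 1, compound 2 and compound 3 also give limits, and no step from any of them to compound 4 can be read. The compounds shown leave open whether fluoro, chloro or methyl on the aromatic carbon makes any difference in this read-out.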